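From 2-cyanophenyl to 3-bromophenyl: compound 3 to compound 4

This account rests on a few compounds, and the source may have more. Where it says the series, first, only, none or still open, it means among the compounds named here.

Measured in a functional assay on HUVEC cells (Homo sapiens) for antiproliferative activity, read by MTT assay, with a stated time of 24 h; a higher number here means a weaker inhibitor, a lower number a stronger inhibitor:
- compound 1 `COc1cc(OC)c(-c2coc3cc(OCc4ccccc4)ccc3c2=O)cc1OC`: 9750 nM
- compound 2 `COc1cc(OC)c(-c2coc3cc(OCc4ccc(Br)cc4)ccc3c2=O)cc1OC`: > 10000 nM (a limit, not a number)
- compound 3 `COc1cc(OC)c(-c2coc3cc(OCc4ccccc4C#N)ccc3c2=O)cc1OC`: > 10000 nM (a limit, not a number)

Compound 3 has no exact value, only a limit of the assay. Compound 3 therefore stands at the limit of > 10000 nM in this assay, at which 2 of the 3 values shown sit. Its reading shows only that it gave no measurable value within the range tested, so any step starting from it is loosely defined.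

The next structure is compound 4 `COc1cc(OC)c(-c2coc3cc(OCc4cccc(Br)c4)ccc3c2=O)cc1OC`. The change is 3-bromophenyl in place of 2-cyanophenyl on a saturated chain carbon bound to an oxygen on an aromatic ring.

Going by the values given here, three measured steps bear on this. Putting bromo on the ring gave an at least 1.0-fold higher number from compound 1 to compound 2 (0.01 log units; that floor lies within the scatter). Putting cyano on the ring gave an at least 1.0-fold higher number from compound 1 to compound 3 (0.01 log units; that floor lies within the scatter). The closest comparison, between the two ring-substituted compounds, is a step that the two limits leave unreadable from compound 2 to compound 3. None of these shows a change beyond the scatter, so no clear step is expected in this assay, in either direction. The expected step is a number no higher from compound 3 to compound 4 (the limit leaves the size open). Compound 4 may also return only a limit. Compound 4 is estimated at 10000 nM, with an expected range of 4000 nM to 25000 nM.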

Compound 4, half-maximal inhibitory concentration: > 10000 nM
Compound 4: no number, only a limit; the forecaster's own chance of this, stated with the estimate: 60%; the middle value lies on the limit itself.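

Compound 4 places a third substituted ring on a saturated chain carbon bound to an oxygen on an aromatic ring, and in this assay its reading is again a limit of the assay, so the set now stands as follows: the limit of > 10000 nM in this assay, at which 3 of the 4 values shown sit.

Going by these compounds alone, the one readable new step, bromo in place of hydrogen on an aromatic carbon, is an at least 1.0-fold higher number from compound 1 to compound 4 (0.01 log units; that floor lies within the scatter), so it shows no change beyond the scatter, although the true size of the step stays open. The steps to compound 4 from compound 2 and from compound 3 cannot be read, so 3-bromophenyl cannot be ranked against 4-bromophenyl or 2-cyanophenyl.

The compounds shown carry only bromo or cyano on this ring, so it remains open whether an amine or a carboxylic acid there would give a measurable value in this assay. Going by these compounds, it also remains open whether a longer chain in place of the single saturated carbon would move the reading away from the limit.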